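This account rests on a few compounds, and the source may have more. Where it says the series, first, only, none or still open, it means among the compounds named here.

Of the compounds shown here, three built on a shared fused two-ring core have been tested in a functional assay on HCT-116 cells (Homo sapiens) for inhibition, read by CCK-8 assay, with a stated time of 48 h; on this read-out higher numbers stand for weaker inhibition and lower numbers for stronger inhibition. Compound 2 `COc1cc(-c2ccnc3cc(-c4ccccc4)nn23)cc(OC)c1OC` gives 3880 nM, the highest of the three numbers. Compound 1 `Cn1ccc2cc(-c3cc4nccc(-c5ccc(F)cc5)n4n3)ccc21` gives 2160 nM, within the scatter of compound 2, while compound 3 `COc1cc(-c2ccnc3cc(-c4ccc5ccn(C)c5c4)nn23)cc(OC)c1OC` gives 1040 nM. Among the compounds with values here, the only single-point step available is a 3.7-fold lower number from compound 2 to compound 3 (0.57 log units; beyond the scatter). Compound 4 `COc1ccc(-c2cc3nccc(-c4cc(OC)c(OC)c(OC)c4)n3n2)cc1N` changes compound 2 at the same aromatic carbon of the five-membered aromatic ring with 2 nitrogen: 3-amino-4-methoxyphenyl in place of phenyl on an aromatic carbon. Because a 3.7-fold lower number from compound 2 to compound 3 (0.57 log units; beyond the scatter) came from exchanging the same phenyl for a larger ring system, a smaller but similar lowering is expected here for compound 4. In this assay compound 4 is estimated at 1800 nM, between 600 nM and 5500 nM. This corresponds to an expected 2.2-fold lower number from compound 2 to compound 4 (0.33 log units; beyond the scatter).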

Compound 4, half-maximal inhibitory concentration: 251 nM
Beside the measured number, compound 4's estimate is 7.2-fold (0.86 log units) above it, and the stated range ends above it.
By their numbers in this assay, from the lowest: compound 4; then compound 3; then compounds 1 and 2 (each within the scatter of the next).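

Exchanging the phenyl at this aromatic carbon for 3-amino-4-methoxyphenyl gives a 15-fold lower number from compound 2 to compound 4 (1.19 log units; beyond the scatter) and so reaches well past what the larger ring system achieved. The same group also outperforms 1-methyl-1H-indol-6-yl, with a 4.1-fold lower number from compound 3 to compound 4 (0.62 log units; beyond the scatter) at this carbon, so the number here depends strongly on which ring group sits at this position.

Going by these compounds, whether the amino group, the methoxy group or the pair carries the gain stays open, and so does whether a hydroxyl in the amino group's place would serve as well. Nothing measured here explains the gain.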